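Carbonyl substituent variation from compound 3 to compound 4

The source may report more compounds than this note shows. Statements on the series, on what has been measured and on what is new or still open speak of the compounds shown alone.

Measured compounds:
compound 1, `Cc1nc(S(C)(=O)=O)ccc1Oc1ncnc(OC2CCN(C(=O)OC3(C(F)(F)F)COC3)CC2)c1F`, gives 29.3 nM in a functional assay on isolated protein for inhibition of Glucose-dependent insulinotropic receptor (Homo sapiens), read by HTRF and cAMP accumulation; a higher number here means that more compound is needed for the effect, a lower number that less compound is needed
compound 2, `Cc1nc(S(C)(=O)=O)ccc1Oc1ncnc(OC2CCN(C(=O)SC3CCC3)CC2)c1F`, gives 8.51 nM in this assay
compound 3, `Cc1nc(S(C)(=O)=O)ccc1Oc1ncnc(OC2CCN(C(=O)C3(F)CCC3)CC2)c1F`, gives 24.7 nM in this assay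

Compound 3 stands second highest of the three numbers in this assay. Its nearest neighbour is compound 1: the step of a 1.2-fold lower number from compound 1 to compound 3 (0.07 log units; within the scatter) lies within the scatter. Its furthest is compound 2: the step of a 2.9-fold higher number from compound 2 to compound 3 (0.46 log units; beyond the scatter) is modest and beyond the scatter. All three compounds share the same core and differ only in the group on the carbonyl carbon whose other neighbour is the amide-type nitrogen in a ring.

Compound 4, `Cc1nc(S(C)(=O)=O)ccc1Oc1ncnc(OC2CCN(C(=O)C3(C)CC3)CC2)c1F`, continues this variation: a group of 4 heavy atoms (4 carbon; one three-membered non-aromatic ring of carbon only) in place of a group of 5 heavy atoms (4 carbon, 1 fluorine; one four-membered non-aromatic ring of carbon only), on a carbonyl carbon. Both measured steps bear on this position. The step of a 1.2-fold lower number from compound 1 to compound 3 (0.07 log units; within the scatter) shows that exchanging one four-membered ring group for another at this carbonyl can leave the number within the scatter, while a 2.9-fold higher number from compound 2 to compound 3 (0.46 log units; beyond the scatter) shows that a modest step is also possible. Within the data shown here, no measured step exchanges a four-membered carbon ring for a three-membered one, so the direct bearing is limited. On this basis a step within the scatter is expected in this assay, with no direction claimed.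

Compound 4 is therefore estimated at 20 nM, with a range of 8 nM to 50 nM, which means an expected step of a 1.2-fold lower number from compound 3 to compound 4 (0.09 log units; within the scatter).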

Compound 4, half-maximal effective concentration: 761 nM
For compound 4 the middle estimate is 38-fold (1.58 log units) below the measured one; measured number above the stated range.
By their numbers in this assay, from the lowest: compound 2; then compounds 3 and 1 (each within the scatter of the next); then compound 4.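

In this assay, among these compounds, this carbonyl position proves far less tolerant than the earlier compounds suggested: the 1-methylcyclopropyl group gives the large steps of a 31-fold higher number from compound 3 to compound 4 (1.49 log units; beyond the scatter) and a 26-fold higher number from compound 1 to compound 4 (1.41 log units; beyond the scatter) and an 89-fold higher number from compound 2 to compound 4 (1.95 log units; beyond the scatter) against all three earlier groups. Until now, the steps among groups at this position were at most modest, so similar heavy-atom counts on the carbonyl carbon do not ensure similar numbers, and the series now has a steep change at this place. Nothing available here accounts for the size of these steps.

The step from the fluorine-bearing four-membered carbon ring group to 1-methylcyclopropyl changes ring size and removes fluorine together, so the compounds shown leave open which change carries it; 1-methylcyclobutyl and 1-fluorocyclopropyl groups on the carbonyl carbon would separate the two. On these data alone, it also remains open how a cyclobutylamino group at the same carbonyl carbon would compare with the cyclobutylsulfanyl group.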